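This account rests on a few compounds, and the source may have more. Where it says the series, first, only, none or still open, it means among the compounds named here.

Compound 2 `O=C(C1=C(Nc2ccccc2)C(=O)N(CCCn2ccnc2)C1c1ccc(Br)cc1)c1ccccc1` gives 25700 nM in a functional assay on U2OS cells (Homo sapiens) for antiproliferative activity, read by MTT assay, with a stated time of 72 h (on this read-out lower numbers stand for stronger inhibition and higher numbers for weaker inhibition), the higher of the two numbers in hand; compound 1 `CCCCCOC1=C(C(=O)c2ccccc2)C(c2ccc(Br)cc2)N(CCCn2ccnc2)C1=O` gives 9140 nM, and the step between them is a 2.8-fold higher number from compound 1 to compound 2 (0.45 log units; beyond the scatter). Compound 3 `Cc1ccc(NC2=C(C(=O)c3ccccc3)C(c3ccc(Br)cc3)N(CCCn3ccnc3)C2=O)cc1` differs from compound 2 by methyl in place of hydrogen on an aromatic carbon. Among the measured compounds shown here, the one measured step concerns exchange of the whole group on the ring carbon, not a substituent on the anilino ring, so no measured step bears directly on this change. The expected step is a 1.0-fold lower number from compound 2 to compound 3 (0.01 log units; within the scatter), nothing beyond the scatter. Compound 3 is therefore estimated at 25000 nM, with a range from 9000 nM to 70000 nM.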

Compound 3, half-maximal inhibitory concentration: 24100 nM
Beside the measured number, compound 3's estimate is 1.0-fold (0.02 log units) above it; low and high end bracket the measured number.
By their numbers in this assay, from the lowest: compound 1; then compounds 3 and 2 (each within the scatter of the next).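

At the aromatic carbon para to a large group, phenyl to 4-methylphenyl on the anilino nitrogen gives no change beyond the scatter in this assay (a 1.1-fold lower number from compound 2 to compound 3 (0.03 log units; within the scatter)). With (4-methylphenyl)amino in place of pentyloxy, the step from the alkoxy compound also stays beyond the scatter (a 2.6-fold higher number from compound 1 to compound 3 (0.42 log units; beyond the scatter)). Nothing available explains either result.

From the compounds shown here alone, whether chloro, methoxy or a carboxylic acid at this ring carbon would shift the number remains open. So does the effect of methyl at other carbons of this ring.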